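The source may hold more compounds than are shown below. What is called first, only, known or untested is meant among the compounds shown, and "the series" means these compounds.

Three compounds share one core and were read in a functional assay on HEK293 cells for agonist activity at D(4) dopamine receptor (Homo sapiens), read by FLIPR; on this read-out lower numbers stand for smaller maximal responses and higher numbers for larger maximal responses. Compound 1 `O=C(CN1CCC(c2cccc[n+]2[O-])CC1)Nc1cccc(Cl)c1` gives 76%, and compound 3 `Cc1cc(C(=O)NCN2CCC(c3cccc[n+]3[O-])CC2)ccc1F` gives 67%. Compound 2 `Cc1cccc(NC(=O)CN2CCC(c3ccc(O)cc3)CC2)c1` gives 60%, the lowest of the three numbers; its gap to compound 3 lies within the scatter of the method, whereas its gap to compound 1 lies beyond it, so only compound 1 can be said to exceed compound 2.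

The unmeasured compound 4 `Cc1cccc(NC(=O)CN2CCC(c3cccc(C#N)n3)CC2)c1` differs from compound 2 in a single place: 6-cyanopyridin-2-yl in place of 4-hydroxyphenyl on a saturated ring carbon. No measured pair among these three shows what such an exchange does, and the two compounds bearing a pyridine nitrogen-oxide are not the same change, so nothing can be read across from them. The expectation for compound 4 therefore rests on the narrow band spanned by the three values. Compound 4 is estimated to give 68% in this assay, with a range from 52% to 84%. This corresponds to an expected step of a number 8 percentage points higher from compound 2 to compound 4 (within the scatter), a modest rise that may well remain within the scatter.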

Compound 4, largest response reached (reported as efficacy), in percent of the reference or control that the assay uses: 42%
For compound 4 the middle estimate is 26 percentage points above the measured one; the measured number lies below the stated range.
By their numbers in this assay, from the lowest: compound 4; then compounds 2, 3 and 1 (each within the scatter of the next, the first and the last beyond it).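

In this assay, putting 6-cyanopyridin-2-yl in place of 4-hydroxyphenyl on the saturated ring carbon goes with a number 18 percentage points lower from compound 2 to compound 4 (beyond the scatter), the only single-place step among the compounds shown. For the compounds shown here, this shows that the maximal response depends on the group at this position, three ring bonds from the ring nitrogen, which the earlier compounds could not show because no two of them differ in one place only. No measurement available here accounts for the size or direction of this step.

Going by these compounds alone, the single exchange changes the ring, adds a nitrile and removes the hydroxyl all at once, so the share of each in the step remains open. A pyridine ring without the nitrile, a phenyl ring carrying a nitrile, or a methoxy group in place of the hydroxyl would each remain to be compared with compound 2.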